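Replacing dimethylamino on a carbonyl carbon in mouse microsomes

The source may report more compounds than this note shows. Statements on the series, on what has been measured and on what is new or still open speak of the compounds shown alone.

Compound 1: `Cn1cc(CNS(=O)(=O)c2ccccc2Nc2cc(-c3ccc4ccn(C)c4c3)c3nccnc3c2)cn1`, 0.267 h
Compound 2: `CN(C)C(=O)c1ccncc1Nc1cc(-c2ccc3ccn(C)c3c2)c2nccnc2c1`, 0.35 h

Two compounds with a shared core have been run in an ADME assay on microsomes from liver (Mus musculus, strain CD-1) for metabolic stability, read by LC-MS, tested at 2 uM; a higher number here means that the compound lasts longer, a lower number that the compound disappears faster. In this assay compound 1 gives 0.267 h, and compound 2 gives 0.35 h. Compound 2 stands with the higher of the two numbers, yet the gap to compound 1 is within the scatter, so the two cannot be told apart on these data.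

Compound 3, `CC(=O)N1CCOC(CNC(=O)c2ccncc2Nc2cc(-c3ccc4ccn(C)c4c3)c3nccnc3c2)C1`, has not yet been measured. It differs from compound 2 in one place: ((4-acetylmorpholin-2-yl)methyl)amino in place of dimethylamino on a carbonyl carbon. Among the measured compounds shown here, no step between measured compounds bears on this change, so the expectation rests only on the two values in hand, which lie within the scatter of each other and offer no direction.

Compound 3 is therefore expected to sit close to compound 2 in this assay, with an estimate of 0.4 h, between 0.2 h and 0.8 h. The expected step of a 1.1-fold higher number from compound 2 to compound 3 (0.06 log units; within the scatter) is estimated as none beyond the scatter.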

Compound 3, half-life: 0.217 h
The estimate for compound 3 lay 1.8-fold (0.27 log units) above the measured number, and the stated range covers the measured number.
By their numbers in this assay, from the lowest: compounds 3, 1 and 2 (each within the scatter of the next).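

In this assay, placing ((4-acetylmorpholin-2-yl)methyl)amino in place of dimethylamino on a carbonyl carbon gives a 1.6-fold lower number from compound 2 to compound 3 (0.21 log units; within the scatter), so the two compounds cannot be told apart on this read-out. Among the compounds shown here, this is the first step at this position, and it shows that a group of 11 heavy atoms, with a six-membered non-aromatic ring and 1 hydrogen-bond donor, can enter in place of one of 3 heavy atoms, none of them in a ring, without a difference beyond the scatter. No measurement shown here accounts for this result.

This single step changes the size of the group, the ring, the acetyl and the donor count all at once, so it cannot assign any part of the result to any one of these features. On these data alone, it remains open whether another group on this carbonyl carbon, such as methylamino, morpholin-4-yl or the same ((morpholin-2-yl)methyl)amino without its acetyl, would give a half-life beyond the scatter of compound 2.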